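This account rests on a few compounds, and the source may have more. Where it says the series, first, only, none or still open, it means among the compounds named here.

Compound 1 `CC1=NN(C(=O)CN2CCCCC2)C(c2ccccc2O)C1`: 4310 nM
Compound 2 `Cc1ccc(C(=O)N2N=C(c3cc4ccccc4oc3=O)CC2c2ccccc2)cc1`: 31300 nM

In a functional assay on MGC-803 cells (Homo sapiens) for cytotoxicity, read by MTT assay, with a stated time of 48 h (on this read-out higher numbers stand for weaker inhibition and lower numbers for stronger inhibition), compound 2 gives 31300 nM. This is the higher of the two numbers and so the weaker inhibition, while compound 1 gives 4310 nM, and the gap between them lies beyond the usual scatter.

The next compound to be tested is compound 3 `CCCNCC(=O)N1N=C(c2cc3ccccc3oc2=O)CC1c1ccccc1`. It keeps the rest of compound 2 and differs in one place, with (propylamino)methyl in place of 4-methylphenyl on a carbonyl carbon.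

Among the compounds with values here, no measured pair isolates this change, so the expectation rests on little. With compound 2 at the top of the range so far, and compound 1 the only reference point at 4310 nM, a move toward stronger inhibition seems more likely than a move toward weaker inhibition. The expected change is a 2.8-fold lower number from compound 2 to compound 3 (0.45 log units; beyond the scatter), a moderate step that is estimated to lie only a little beyond the scatter. For compound 3 the estimated value in this assay is 11000 nM, with an expected range from 3500 nM to 35000 nM.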

Compound 3, half-maximal inhibitory concentration: 4880 nM
Estimate against measurement, compound 3: 2.3-fold (0.35 log units) above, and the stated range covers the measured number.
By their numbers in this assay, from the lowest: compounds 1 and 3 (each within the scatter of the next); then compound 2.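

In this assay, within the data shown here, the pair of compound 2 and compound 3 gives the first reading of the group on a carbonyl carbon whose other neighbour is amide-type nitrogen in a ring: putting (propylamino)methyl in place of 4-methylphenyl gives a 6.4-fold lower number from compound 2 to compound 3 (0.81 log units; beyond the scatter). The number at this position therefore responds to the group it carries, and the aromatic ring of 4-methylphenyl is not needed for the stronger inhibition seen with compound 3. The exchange removes that ring and brings in a nitrogen, a hydrogen-bond donor and a hydrogen-bond acceptor all at once, and no measurement at hand explains the step.

The compounds shown leave open whether the step follows the loss of the aromatic ring or the arrival of the amine, a question that a plain butyl chain or a (phenylamino)methyl group on the same carbonyl carbon would help to separate. They also leave open how the number would respond to a longer chain such as (hexylamino)methyl, or to a carboxylic acid at the end of the chain.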